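The source may hold more compounds than are shown below. What is called first, only, known or untested is meant among the compounds shown, and "the series" means these compounds.

Measured compounds:

Compound 1, `Nc1ccccc1NC(=O)c1ccc(CSc2cccc(F)c2)cc1`, 83%
Compound 2, `Nc1ccccc1NC(=O)/C=C/c1ccc(CSc2cccc3ccccc23)cc1`, 18.3%

The series was characterised in a functional assay on SMMC-7721 cells (Homo sapiens) for inhibition, read by CCK-8 assay, with a stated time of 72 h, tested at 8 uM; on this read-out higher numbers stand for more inhibition of growth at the one concentration tested and lower numbers for less inhibition of growth. In this assay compound 1 gives 83%, the highest of the two numbers recorded. Compound 2 gives 18.3%, a number that lies far below that of compound 1, beyond the usual scatter; since these two compounds differ in more than one place, nothing more than the two values themselves can be read from the pair.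

The account now follows the step from compound 1 to compound 3, `Nc1ccccc1NC(=O)c1ccc(CSc2ccc(Cl)cc2)cc1`, which has not yet been measured in this assay. The structural difference between them is a single exchange at one point: 4-chlorophenyl in place of 3-fluorophenyl on a sulfur

Both halophenyl groups sit on the same sulfur and carry the same count of heavy atoms, with no change in donors or acceptors. With no measured step of this kind in the set, the expected step from compound 1 to compound 3 is estimated as a number 6 percentage points lower from compound 1 to compound 3 (within the scatter), a change that may well fall within the scatter, with a slight lean downward. Compound 3 is therefore expected to give about 77%, within a range from 58% to 92%.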

Compound 3, percent growth inhibition at one concentration: 16.5%
Compound 3: middle estimate off by 60.5 percentage points, on the high side; the measured number lies below the stated range.
By their numbers in this assay, from the lowest: compounds 3 and 2 (each within the scatter of the next); then compound 1.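

In this assay, for the compounds shown here, the exchange of 3-fluorophenyl for 4-chlorophenyl on a sulfur whose other neighbour is a saturated chain carbon is the first change in a single place to be read, and it gives a large step, a number 66.5 percentage points lower from compound 1 to compound 3 (beyond the scatter). This shows that the read-out at this position depends strongly on which halophenyl group the sulfur carries, even though the two groups have the same count of heavy atoms and the same counts of hydrogen-bond donors and acceptors, so these counts do not separate compound 1 from compound 3. No measurement at hand accounts for the size of this step.

The halogen and its place on the ring change together in this step, so the compounds shown leave open which of the two carries it. Going by these compounds, it also remains open how the read-out would respond to a plain phenyl or a benzyl group on the same sulfur, and whether such a group would stand nearer to compound 1 or to compound 3.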